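From Methoxy to Nitro on a Diiodo Salicyl Hydrazide

A few compounds are considered here, and "the series" means these few. Any claim that something is new, unique, unknown or untested is made for them only; others in the source may bear on it.

Compound 1, `Cc1ccc(C(=O)N/N=C/c2cc(I)c(O)c(I)c2)cc1`, in a functional assay on HepG2 cells (Homo sapiens) for cytotoxicity, with a stated time of 24 h (a higher number here means a weaker inhibitor, a lower number a stronger inhibitor), gives > 100000 nM, which is a limit of the assay rather than a number.
Compound 2, `O=C(N/N=C/c1cc(I)c(O)c(I)c1)c1ccc(Br)cc1`, in this assay gives > 50000 nM, again a limit rather than a number.
Compound 3, `COc1ccc(C(=O)NNC(=O)c2cc(I)cc(I)c2O)cc1`, in this assay gives 132000 nM.

Compound 3 is thus the only one of the three with an actual number; the other two values are limits, one sitting at the limit of > 100000 nM in this assay, at which 1 of the 3 values shown sits, and one at the limit of > 50000 nM in this assay, at which 1 of the 3 values shown sits. All three point to very weak inhibition of these liver-derived cells. Going by the values given here, the only measured pair that differs in a single place is compound 1 and compound 2, and a step that the two limits leave unreadable from compound 1 to compound 2 is a step that the two limits leave without a readable size.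

Compound 4, `O=C(NNC(=O)c1cc(I)cc(I)c1O)c1ccc([N+](=O)[O-])cc1`, differs from compound 3 by nitro in place of methoxy on an aromatic carbon. Among the compounds with values here, no measured step touches this change, and the one step on record gives no size to lean on. Since compound 3 sits at 132000 nM, the expectation is that compound 4 stays in the same very weak region, with a step of a 1.1-fold lower number from compound 3 to compound 4 (0.04 log units; within the scatter) that lies within the scatter. Compound 4 is therefore estimated at 120000 nM, ranging from 40000 nM to 350000 nM.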

Compound 4, half-maximal inhibitory concentration: 159000 nM
Compound 4: the middle estimate sits 1.3-fold (0.12 log units) below what was measured; low and high end bracket the measured number.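

At this place on the aromatic ring, para to a large group, a change of substituent now has a readable size: in this assay, nitro in place of methoxy gives a 1.2-fold higher number from compound 3 to compound 4 (0.08 log units; within the scatter). Going by these compounds alone, the only earlier step could not be read, so this pair is the first to put a number on a single change. Nitro brings more heavy atoms and more hydrogen-bond acceptors than methoxy, yet compound 3 and compound 4 cannot be told apart in this assay, and both remain very weak inhibitors of these cells. Nothing measured here explains why these two groups read alike.

The compounds shown leave open whether any group at this position could give a number clearly apart from these two, for example an amine or a carboxylic acid. From the compounds shown here alone, it also remains open whether methoxy and nitro would read alike on the core of compound 1, so this result cannot yet be taken as a rule for the wider series.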